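Swapping a phosphate for an amino acid on a sulfonamide

The compounds below may be only part of what the source reports. "The series", "measured", "known", "first", "only" and "open" are said of these compounds alone.

Compound 1 `COc1ccc(NS(=O)(=O)/C=C/c2ccccc2OC)cc1`: 5000 nM
Compound 2 `COc1ccc(NS(=O)(=O)/C=C/c2ccc(OC)cc2OC)cc1`: 15000 nM
Compound 3 `COc1cc(OC)c(/C=C/S(=O)(=O)Nc2ccc(OC)c(OP(=O)(O)O)c2)c(OC)c1`: 7.5 nM

Three compounds share a styryl sulfonamide core and were tested in a functional assay on K562 cells (Homo sapiens) for cytotoxicity, read by trypan blue exclusion, with a stated time of 96 h; a lower number here means a stronger inhibitor, a higher number a weaker inhibitor. Compound 1 gives 5000 nM, and adding one methoxy group gives compound 2 at 15000 nM, a step of a 3.0-fold higher number from compound 1 to compound 2 (0.48 log units; beyond the scatter). Compound 3 gives 7.5 nM and stands lowest of the three by a wide margin, its gaps to both others lying well outside the usual scatter.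

Compound 4 `COc1cc(OC)c(/C=C/S(=O)(=O)Nc2ccc(OC)c(NC(C)(C)C(=O)O)c2)c(OC)c1` differs from compound 3 in one place: a group of 7 heavy atoms (4 carbon, 1 nitrogen, 2 oxygen; no ring) in place of a group of 5 heavy atoms (4 oxygen, 1 phosphorus; no ring), on an aromatic carbon. For the measured compounds named here, the only measured step, from compound 1 to compound 2, concerns an added methoxy group and does not bear on this exchange, so there is no measured guide for it. The change keeps the same counts of hydrogen-bond donors and acceptors and sits at the same position, so the number for compound 4 is expected to stay close to that of compound 3, with a modest upward step of a 2.7-fold higher number from compound 3 to compound 4 (0.43 log units; beyond the scatter) allowed. Compound 4 is estimated at 20 nM, within 5 nM to 100 nM.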

Compound 4, half-maximal inhibitory concentration: 5 nM
Compound 4: middle estimate off by 4.0-fold (0.60 log units), on the high side, and the stated range covers the measured number.
By their numbers in this assay, from the lowest: compounds 4 and 3 (each within the scatter of the next); then compound 1; then compound 2.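

In this assay, the (1-carboxy-1-methylethyl)amino group of compound 4 replaces the phosphate of compound 3 with a 1.5-fold lower number from compound 3 to compound 4 (0.18 log units; within the scatter), so this assay does not tell the two groups apart. For the compounds shown here, the only earlier step concerned an added methoxy group, whereas this exchange shows that, on this aromatic carbon ortho to a methoxy group, a group without phosphorus can give a number in the same low range. Nothing measured here explains why two such different groups give matching numbers.

From the compounds shown here alone, it remains open whether a plain amine, or a hydroxyl group, at this position would keep the number this low. The compounds shown also cannot separate the contribution of the carboxylic acid from that of the linking nitrogen or the two methyl groups.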